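Trimming the amine side chain in a biaryl series

The source may report more compounds than this note shows. Statements on the series, on what has been measured and on what is new or still open speak of the compounds shown alone.

The compounds here share one core, carrying an amine on a saturated chain carbon bound to an aromatic carbon. Compound 1 `CCCN(CCC)Cc1ccc(Cl)c(-c2ccccc2OC)c1` carries a dipropylamino group there. In a functional assay on HEK293 cells for agonist activity at 5-hydroxytryptamine receptor 7 (Homo sapiens), read by a luciferase reporter and beta-arrestin recruitment, with a stated time of 22 h (on this read-out higher numbers stand for an effect only at larger amounts of compound and lower numbers for an effect already at smaller amounts), compound 1 gives "not active" (no number reported), so no number stands for it. A second compound, compound 2 `COc1ccccc1-c1cc(CN(C)C)ccc1Cl`, has been measured in the same setting: in this assay compound 2 gives 479 nM; 480 nM (2 entries), and the several entries of compound 2 in this assay, 479 nM; 480 nM (2 entries) shows how closely its entries agree.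

Compound 3 `CCN(CC)Cc1ccc(Cl)c(-c2ccccc2OC)c1` is the next point. It differs from compound 1 in one place, (diethylamino in place of dipropylamino on a saturated chain carbon bound to an aromatic carbon).

For the measured compounds named here, no measured step between two compounds frames this change, so the size of the step is open. Since compound 1 has no number in this assay, the step from compound 1 to compound 3 can only be judged by whether compound 3 yields a number at all. The expectation is a move toward an effect at smaller amounts, of uncertain size, with a real chance that compound 3 again returns no number. Compound 3 is expected to give about 2500 nM in this assay, within a range from 500 nM to 12000 nM.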

Compound 3, half-maximal effective concentration: "not active" (no number reported)
Compound 3 has no reported number here, so the estimate cannot be set against anything.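

For the compounds shown here, with no number for either compound 1 or compound 3 in this assay, no step between them can be read. Nothing shown here bears on why compound 3 yields no number. Still open, going by these compounds, is whether the amine group alone decides if a number appears, since compound 2 gives 479 nM; 480 nM (2 entries).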